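The compounds below may be only part of what the source reports. "The series", "measured", "known", "first", "only" and "open" are said of these compounds alone.

Of the compounds shown here, three built on one shared core have been measured in an assay on isolated protein for displacement of a labelled ligand from Adrenergic receptor alpha-1 (Rattus norvegicus); on this read-out higher numbers stand for weaker inhibition and lower numbers for stronger inhibition. Compound 1 `COc1cc2nc(N3CCC(C(=O)NC4CCCC4)CC3)nc(N)c2cc1OC` gives 0.63 nM, compound 2 `COc1cc2nc(N3CCC(C(=O)NCC4CC4)CC3)nc(N)c2cc1OC` gives 0.9 nM, and compound 3 `CCCNC(=O)CC1CCN(c2nc(N)c3cc(OC)c(OC)cc3n2)CC1` gives 0.65 nM. Among these three numbers, that of compound 3 is the second highest, and its gaps to both neighbours lie within the scatter: a 1.0-fold higher number from compound 1 to compound 3 (0.01 log units; within the scatter), and a 1.4-fold lower number from compound 2 to compound 3 (0.14 log units; within the scatter). The remaining step, a 1.4-fold higher number from compound 1 to compound 2 (0.15 log units; within the scatter), is likewise within the scatter, so the three values cannot be told apart.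

Compound 4 `CCCCNC(=O)CCC1CCN(c2nc(N)c3cc(OC)c(OC)cc3n2)CC1` has not yet been measured. Relative to compound 3 the change is (butylcarbamoyl)methyl in place of propylcarbamoyl on a saturated chain carbon bound to a saturated ring carbon. All three measured steps bear on this change, since each of them also alters either the group on the amide-type nitrogen or the link between the amide and the saturated ring carbon, and none of them moved the number beyond the scatter. A longer chain at this position is therefore expected to leave the number essentially where it is, with no step beyond the scatter in either direction. Compound 4 is expected to give about 0.7 nM, with a range from 0.35 nM to 1.4 nM. This estimate corresponds to a 1.1-fold higher number from compound 3 to compound 4 (0.03 log units; within the scatter), expected to remain within the scatter.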

Compound 4, inhibition constant: 0.47 nM
Compound 4: the middle estimate sits 1.5-fold (0.17 log units) above what was measured; the range from low to high includes it.
By their numbers in this assay, from the lowest: compounds 4, 1, 3 and 2 (each within the scatter of the next).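

In this assay, the group on a saturated chain carbon bound to a saturated ring carbon grows from propylcarbamoyl, with 6 heavy atoms, to (butylcarbamoyl)methyl, with 8, and the number stays within the scatter (a 1.4-fold lower number from compound 3 to compound 4 (0.14 log units; within the scatter)). Within the data shown here, earlier steps had altered either the group on the amide nitrogen or the link to the saturated ring carbon, whereas this one lengthens the chain on both sides of the amide and still produces no step that can be told from ordinary scatter. The comparisons of 2-(butylcarbamoyl)ethyl with the groups of the other two compounds also remain within the scatter (a 1.9-fold lower number from compound 2 to compound 4 (0.28 log units; within the scatter); a 1.3-fold lower number from compound 1 to compound 4 (0.13 log units; within the scatter)), and no measurement is available to explain why these numbers stay so close.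

All four values thus remain indistinguishable, so the compounds shown give no ranking and do not reveal how much longer this side chain could become before the number moves beyond the scatter. They also leave open what would happen with a much longer chain, such as octylcarbamoyl, or if an amine or a carboxylic acid replaced the amide.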